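Pyridin-4-yl in Place of 3-Chlorophenyl: Platelet Inhibition

The compounds below may be only part of what the source reports. "The series", "measured", "known", "first", "only" and "open" are said of these compounds alone.

Measured compounds in a functional assay on cells (Platelet, Homo sapiens) for inhibition; on this read-out higher numbers stand for weaker inhibition and lower numbers for stronger inhibition:
compound 1 `CCOC(=O)c1ccc(-c2nn(Cc3cccc(Cl)c3)c3ccccc23)cc1` gives > 10000 nM, a limit of the assay
compound 2 `CCOC(=O)c1ccc(-c2nn(Cc3cccc(OC)c3)c3ccccc23)cc1` gives > 10000 nM, a limit of the assay
compound 3 `CCOC(=O)c1ccc(-c2nn(Cc3cccnc3)c3ccccc23)cc1` gives > 10000 nM, a limit of the assay

Among the compounds with values here, compound 1 stands only at a limit in this assay, and the two other values are limits as well, so no compound can be placed above or below another. All three sit at the limit of > 10000 nM in this assay, at which 3 of the 3 values shown sit. The steps between them are correspondingly unreadable: a step that the two limits leave unreadable from compound 1 to compound 2, a step that the two limits leave unreadable from compound 1 to compound 3 and a step that the two limits leave unreadable from compound 2 to compound 3.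

Compound 4 `CCOC(=O)c1ccc(-c2nn(Cc3ccncc3)c3ccccc23)cc1` has not yet been measured in this assay. It differs from compound 1 as follows: pyridin-4-yl in place of 3-chlorophenyl on a saturated chain carbon bound to an aromatic nitrogen. Within the data shown here, the step that bears most closely on this change is the one from compound 1 to compound 3, where a pyridinyl group also replaces the 3-chlorophenyl on the saturated chain carbon bound to an aromatic nitrogen; that step could not be read, since both values are limits. Nothing in the measured steps therefore points to a shift in this assay in either direction beyond the scatter, and the expectation is that compound 4 will again fall at the limit. The estimated step from compound 1 to compound 4 is a step that the limit leaves unreadable from compound 1 to compound 4. Compound 4 is thus estimated at 20000 nM, expected between 8000 nM and 60000 nM.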

Compound 4, half-maximal inhibitory concentration: > 10000 nM
Compound 4 ended at the assay's limit (the forecaster's own chance of this, stated with the estimate: 85%); the middle value does not contradict the limit.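

In this assay compound 4 gives > 10000 nM, a limit of the assay. Its steps from compound 1, compound 2 and compound 3 therefore cannot be read, and all four compounds stand together: the limit of > 10000 nM in this assay, at which 4 of the 4 values shown sit.

The compounds shown leave open how strongly any of them inhibits, and whether any change at this place alters the read-out at all.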